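The source may hold more compounds than are shown below. What is called first, only, known or untested is meant among the compounds shown, and "the series" means these compounds.

Measured compounds:
- compound 1, `Clc1ccc(-c2cc(-c3ccco3)cc(-c3ccc(Cl)s3)n2)cc1`, 14800 nM
- compound 2, `Clc1ccc(-c2cc(-c3ccoc3)cc(-c3ccco3)n2)s1`, 17200 nM
- compound 3, `Clc1cccc(-c2cc(-c3ccoc3)cc(-c3ccc(Cl)s3)n2)c1`, 23000 nM

These three compounds share one core and were tested in a functional assay on DU-145 cells (Homo sapiens) for cytotoxicity, read by ELISA, with a stated time of 4 days; on this read-out lower numbers stand for stronger inhibition and higher numbers for weaker inhibition. In this assay compound 1 gives 14800 nM, and its number lies within the scatter of both compound 2 and compound 3. Among the measured compounds shown here, the only step recorded among the three, a 1.3-fold higher number from compound 2 to compound 3 (0.13 log units; within the scatter), also stays within the scatter, so none of the three is set apart from the others.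

Compound 4, `Clc1ccc(-c2cc(-c3ccc(Cl)o3)cc(-c3ccc(Cl)s3)n2)cc1`, differs from compound 1 by chloro in place of hydrogen on an aromatic carbon. For the measured compounds named here, no measured pair in this set shows the same change: the one recorded step swaps a whole ring for another and stays within the scatter, and no pair here adds a chloro group to a furan ring. The data therefore give no ground for expecting a step beyond the scatter in this assay, in either direction.

Compound 4 is accordingly expected to give about 15000 nM in this assay, with a likely range from 7000 nM to 32000 nM. The expected step of a 1.0-fold higher number from compound 1 to compound 4 (0.01 log units; within the scatter) is an estimate of essentially no change.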

Compound 4, half-maximal inhibitory concentration: 23000 nM
Estimate against measurement, compound 4: 1.5-fold (0.19 log units) below; the measured number falls inside the stated range.
By their numbers in this assay, from the lowest: compounds 1, 2, 3 and 4 (each within the scatter of the next).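

Among the compounds shown here, the furan-2-yl to 5-chlorofuran-2-yl change is the first reading of a substitution on this ring rather than a swap of a whole ring, and in this assay it comes to a 1.6-fold higher number from compound 1 to compound 4 (0.19 log units; within the scatter), so the step does not separate the two compounds. For the compounds shown here, this carbon, next to the ring oxygen and two ring bonds from the ring atom that bears a large group, therefore accepts one added chlorine without a change that can be told from the usual variation of this read-out, something the earlier compounds could not show because none of them carried a group on the furan ring. Nothing available here bears on why the added chloro group leaves the number within the scatter.

The compounds shown leave open whether a different group at this same carbon, such as an amine, a carboxylic acid or a longer alkyl chain, would move the number beyond the scatter. They also leave open whether any change on the shared core can reach numbers clearly apart from those of this set.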